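A Methyl Added to the Ring of Compound 3

This account rests on a few compounds, and the source may have more. Where it says the series, first, only, none or still open, it means among the compounds named here.

Of the compounds shown here, three have been measured in an assay on RBL-1 cells for inhibition of Polyunsaturated fatty acid 5-lipoxygenase (Rattus norvegicus); a higher number here means a weaker inhibitor, a lower number a stronger inhibitor. Compound 1 `O=C1NCCN(c2cccc(OCc3ccccc3)c2)N1` gives 1100 nM, compound 2 `O=C1NCCN(c2cccc(-c3ccsc3)c2)N1` gives 4900 nM, and compound 3 `CC1CN(c2ccccc2)NC(=O)N1O` gives 6000 nM. Compound 3 stands at the highest of the three numbers; the gap to compound 2 lies within the scatter, the gap to compound 1 beyond it. Compound 4 `Cc1cccc(N2CC(C)N(O)C(=O)N2)c1` differs from compound 3 by methyl in place of hydrogen on an aromatic carbon, placed meta to a group of 9 heavy atoms. Among the compounds with values here, no measured pair shows this change, so its size is unknown here. The step of a 1.5-fold lower number from compound 3 to compound 4 (0.18 log units; within the scatter) is expected to stay near the scatter, leaning toward a somewhat lower number. Compound 4 is therefore estimated at 4000 nM, with a range from 1500 nM to 10000 nM.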

Compound 4, half-maximal inhibitory concentration: 8400 nM
The estimate for compound 4 lay 2.1-fold (0.32 log units) below the measured number, within the range that was stated.
By their numbers in this assay, from the lowest: compound 1; then compounds 2, 3 and 4 (each within the scatter of the next).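

Methyl in place of hydrogen on an aromatic carbon, meta to a group of 9 heavy atoms, gives a 1.4-fold higher number from compound 3 to compound 4 (0.15 log units; within the scatter) in this assay and provides the first measured size of this change. At this position, methyl therefore leaves the number within the scatter of compound 3. Nothing measured here offers an explanation for this result. From the compounds shown here alone, whether methoxy, chlorine or a carboxylic acid on the same aromatic carbon would move the number beyond the scatter stays open, as does whether methyl would behave alike on other carbons of this ring.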